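The source may hold more compounds than are shown below. What is called first, only, known or untested is meant among the compounds shown, and "the series" means these compounds.

Measured compounds in an assay on HEK293 cells for activation of Kir3.1/Kir3.2 (Homo sapiens), read by thallium flux; on this read-out higher numbers stand for larger maximal responses and lower numbers for smaller maximal responses:

compound 1 `Cc1cc(NC(=O)Cn2nnc(-c3ccccc3)n2)n(C2CCCCC2)n1` — 92%
compound 2 `O=C(Cn1nnc(-c2ccccc2)n1)Nc1cc(C2CC2)nn1C1CCCCC1` — 45%
compound 3 `Cc1cc(NC(=O)Cn2nnc(-c3ccccc3)n2)n(Cc2ccccc2)n1` — 74%

Compound 1 stands highest of the three: the nearest is compound 3, at a number 18 percentage points lower from compound 1 to compound 3 (beyond the scatter), and the furthest is compound 2, at a number 47 percentage points lower from compound 1 to compound 2 (beyond the scatter). Both of those steps change groups on the shared core away from the phenyl ring: one puts cyclopropyl in place of methyl on an aromatic carbon, the other puts benzyl in place of cyclohexyl on an aromatic nitrogen.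

Compound 4 `Cc1cc(NC(=O)Cn2nnc(-c3ccc(F)c(F)c3)n2)n(C2CCCCC2)n1` differs from compound 1 elsewhere: 3,4-difluorophenyl in place of phenyl on an aromatic carbon. No measured step touches this phenyl ring, so the two steps seen so far give no direct guide to the size or direction of the change, only a hint that compound 1 sits near the top of what this assay has shown. Adding two fluorines to the phenyl ring is a small change in size, and the expectation is therefore a step of a number 7 percentage points lower from compound 1 to compound 4 (within the scatter), within or close to the scatter. Compound 4 is expected to give about 85%, with a range from 60% to 105%.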

Compound 4, largest response reached (Emax), in percent of the reference or control that the assay uses: 93%
Beside the measured number, compound 4's estimate is 8 percentage points below it, and the stated range covers the measured number.
By their numbers in this assay, from the lowest: compound 2; then compound 3; then compounds 1 and 4 (each within the scatter of the next).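

Two fluorines on the phenyl ring give, in this assay, a number 1 percentage points higher from compound 1 to compound 4 (within the scatter). This is the only step shown at this position, on an aromatic carbon of a five-membered aromatic ring with 4 nitrogen, and it shows that 3,4-difluorophenyl can take the place of phenyl with no change beyond the scatter, whereas the steps at the other two places, cyclopropyl for methyl and benzyl for cyclohexyl, both lie beyond it. No measurement at hand gives a reason for this result.

On these data alone, it remains open whether this ring keeps the response with a different group on it, such as a methoxy group, an amine or a carboxylic acid. Also open, as far as these compounds go, is whether 3,4-difluorophenyl would give the same response with cyclopropyl or benzyl elsewhere on the shared core.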